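Ester-to-ether swap on a shikonin-type naphthoquinone side chain

The source may report more compounds than this note shows. Statements on the series, on what has been measured and on what is new or still open speak of the compounds shown alone.

Of the compounds shown here, three sharing one core have been tested in a functional assay on HeLa cells (Homo sapiens) for cytotoxicity, read by MTT assay; a lower number here means a stronger inhibitor, a higher number a weaker inhibitor. Compound 1 `CCCCC(O)CC(=O)O[C@H](CC=C(C)C)C1=CC(=O)c2c(O)ccc(O)c2C1=O` gives 72200 nM. Compound 2 `CC(C)=CC[C@@H](OC(=O)C1CCCO1)C1=CC(=O)c2c(O)ccc(O)c2C1=O` gives 17000 nM, the lowest of the three numbers; compound 3 `CC(C)=CC[C@@H](OCC(C)O)C1=CC(=O)c2c(O)ccc(O)c2C1=O` gives 24700 nM. The gap between compound 2 and compound 3 is small, a 1.5-fold higher number from compound 2 to compound 3 (0.16 log units; within the scatter), and lies within the scatter, so the two cannot be ranked; the gap to compound 1 is larger, a 4.2-fold lower number from compound 1 to compound 2 (0.63 log units; beyond the scatter).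

Compound 4 `CC(=O)OC(C)CO[C@H](CC=C(C)C)C1=CC(=O)c2c(O)ccc(O)c2C1=O` is not yet measured. Compared with compound 2, the change is 2-acetoxypropyl in place of (oxolan-2-yl)carbonyl on an oxygen on a saturated carbon. Within the data shown here, two measured steps bear on it. Replacing an ester-linked group by an ether-linked hydroxypropyl gave a 2.9-fold lower number from compound 1 to compound 3 (0.47 log units; beyond the scatter) from the weakest starting point, and a 1.5-fold higher number from compound 2 to compound 3 (0.16 log units; within the scatter) from compound 2. Among the measured compounds shown here, compound 4 keeps the ether linkage of compound 3 but carries an acetyl on the hydroxyl, a change for which no measured pair exists here. The expectation is therefore a step of no clear direction and within the scatter, a 1.3-fold higher number from compound 2 to compound 4 (0.11 log units; within the scatter), placing compound 4 close to compound 2 and compound 3. Compound 4 is estimated at 22000 nM, with a range from 9000 nM to 55000 nM.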

Compound 4, half-maximal inhibitory concentration: 40100 nM
The estimate for compound 4 lay 1.8-fold (0.26 log units) below the measured number; the measured number falls inside the stated range.
By their numbers in this assay, from the lowest: compounds 2, 3, 4 and 1 (each within the scatter of the next, the first and the last beyond it).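

In this assay, among these compounds, putting an acetyl in place of the hydrogen on the hydroxyl of compound 3 gives the first direct look at that hydroxyl, and the effect cannot be read (a 1.6-fold higher number from compound 3 to compound 4 (0.21 log units; within the scatter)). Compound 4 nevertheless separates from compound 2 (a 2.4-fold higher number from compound 2 to compound 4 (0.37 log units; beyond the scatter)), which compound 3 did not do, even though the 2-acetoxypropyl and (oxolan-2-yl)carbonyl groups match in heavy atoms, hydrogen-bond donors and hydrogen-bond acceptors and differ in having no ring or one ring. Compound 4 also stays within the scatter of compound 1 (a 1.8-fold lower number from compound 1 to compound 4 (0.26 log units; within the scatter)), whereas compound 3 lies beyond it, yet nothing measured here gives a reason for any of these steps.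

From the compounds shown here alone, whether a longer chain in place of the acetyl, or an amine or a carboxylic acid in place of the hydroxyl of the 2-hydroxypropyl group, would move the number remains open. Going by these compounds, it is also open whether the five-membered ring of compound 2 would keep its number if joined through an ether rather than an ester.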